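Replacing a Nitrile with Hydroxy: Expected Inhibition of Compound 4

This account rests on a few compounds, and the source may have more. Where it says the series, first, only, none or still open, it means among the compounds named here.

Compound 1 `CN(C)c1ncnc2c1ncn2Cc1ccc(Cl)cc1` gives 0% in a functional assay on the whole organism for inhibition, with Rattus norvegicus as the target, at a dose of 25 mg/kg by the intraperitoneal route; a higher number here means more inhibition at the dose given (going by the name of the read-out), a lower number less inhibition.
Compound 2 `Cc1ccc(Cn2cnc3c(N(C)C)ncnc32)cc1` gives 0% in this assay.
Compound 3 `CN(C)c1ncnc2c1ncn2Cc1ccc(C#N)cc1` gives 0% in this assay.

Compound 3 stands level with compound 1 and compound 2, with all three showing no inhibition. The steps of no change at the digits printed from compound 1 to compound 2 (within the scatter), no change at the digits printed from compound 1 to compound 3 (within the scatter) and no change at the digits printed from compound 2 to compound 3 (within the scatter) all stayed within the scatter, so exchanging chloro, methyl and cyano on this aromatic carbon made no difference in this assay. Compound 4 `CN(C)c1ncnc2c1ncn2Cc1ccc(O)cc1` differs from compound 3 by hydroxy in place of cyano on an aromatic carbon. Because every measured change at this position gave no change at the digits printed from compound 2 to compound 3 (within the scatter) or the like, the step of no change at the digits printed from compound 3 to compound 4 (within the scatter) is expected to stay within the scatter. For compound 4 the expected inhibition in this assay is 0%, within a range from -5% to 15%.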

Compound 4, a percentage reported as inhibition, in the whole organism at one dose (the size of the read-out at that dose, not a potency): 0%
Compound 4: middle estimate and measured number agree at the digits printed; the measured number falls inside the stated range.
By their numbers in this assay, from the lowest: compounds 1, 2, 3 and 4 (each within the scatter of the next).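

Hydroxy counts one hydrogen-bond donor where cyano counts none, yet this assay shows no change at the digits printed from compound 3 to compound 4 (within the scatter) for this swap on the aromatic carbon. Compared with the other two groups, the result is the same: no change at the digits printed from compound 2 to compound 4 (within the scatter) and no change at the digits printed from compound 1 to compound 4 (within the scatter) at this dose. This position has now taken chloro, methyl, cyano and hydroxy with no reading that separates them.

Going by these compounds, whether an amine or a carboxylic acid on this carbon would give a different reading stays open. Nothing available explains why these four readings match.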